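Compound 1 to compound 3: amino in place of hydrogen

This account rests on a few compounds, and the source may have more. Where it says the series, first, only, none or still open, it means among the compounds named here.

- compound 1 `OC[C@@H]1O[C@H](n2cnc3c(O)ncnc32)CC1(F)F` gives > 100000 nM as a limit
- compound 2 `OC[C@@H]1O[C@@H](n2cnc3c(O)ncnc32)CC1(F)F` gives > 100000 nM as a limit

In a functional assay on CCRF-CEM cells (Homo sapiens) for cytotoxicity (on this read-out higher numbers stand for weaker inhibition and lower numbers for stronger inhibition), compound 1 sits at > 100000 nM as a limit, not a number. Compound 3 `Nc1nc(O)c2ncn([C@@H]3CC(F)(F)[C@H](CO)O3)c2n1` keeps the core of compound 1 with one change (amino in place of hydrogen on an aromatic carbon), amino in place of hydrogen on an aromatic carbon. Going by the values given here, the only measured step (a step that the two limits leave unreadable from compound 1 to compound 2) concerns configuration (the fact that compounds 1 and 2 differ only in the configuration as drawn), not this group, and its size cannot be read. Among the compounds with values here, no step of readable size is therefore expected in this assay, and a further limit is the likeliest result. For compound 3 the estimated value is 100000 nM (expected range 30000 nM to 200000 nM). The expected step is a number no higher from compound 1 to compound 3 (the limit leaves the size open) in size, with no direction firmly expected.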

Compound 3, half-maximal inhibitory concentration: > 100000 nM
Compound 3: a limit, no number (the forecaster's own chance of this, stated with the estimate: 75%); the middle value sits exactly at the limit.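

Going by these compounds alone, compound 3 gives > 100000 nM, a limit and not a number, so no step from compound 1 to compound 3 can be read in this assay. The compounds shown leave open whether amino in place of hydrogen on an aromatic carbon shifts this read-out at all.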